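A few compounds are considered here, and "the series" means these few. Any claim that something is new, unique, unknown or untested is made for them only; others in the source may bear on it.

Three compounds share one core and differ only in the length of one saturated chain. Compound 1 `CCOC(=O)CCC(=O)N1CCN(CCCOc2cc3c(Nc4ccc(F)c(Cl)c4)ncnc3cc2OC)CC1` gives 70% in a functional assay on A549 cells (Homo sapiens) for cytotoxicity, read by MTT assay, with a stated time of 24 h, tested at 20 uM; a lower number here means a stronger effect, a higher number a weaker effect of the compound at the concentration tested. Compound 2 `CCCCOC(=O)CCC(=O)N1CCN(CCCOc2cc3c(Nc4ccc(F)c(Cl)c4)ncnc3cc2OC)CC1` gives 86% in this assay, and compound 3 `CCCCCCCCCCOC(=O)CCC(=O)N1CCN(CCCOc2cc3c(Nc4ccc(F)c(Cl)c4)ncnc3cc2OC)CC1` gives 88.2% in this assay. Compound 3 carries the highest of the three numbers, yet its gap to compound 2 lies within the scatter, while the step of a number 18.2 percentage points higher from compound 1 to compound 3 (beyond the scatter) lies beyond it. Compound 4 `CCCCCCCCCCCCCCCCCOC(=O)CCC(=O)N1CCN(CCCOc2cc3c(Nc4ccc(F)c(Cl)c4)ncnc3cc2OC)CC1` extends the same chain further: heptyl in place of hydrogen on a saturated chain carbon, ten or more bonds along the chain from an oxygen next to a carbonyl group. The measured steps that bear on this change are all chain lengthenings. The steps of a number 16 percentage points higher from compound 1 to compound 2 (beyond the scatter) and a number 18.2 percentage points higher from compound 1 to compound 3 (beyond the scatter) were modest, whereas a number 2.2 percentage points higher from compound 2 to compound 3 (within the scatter) stayed within the scatter. Because the latest lengthening a number 2.2 percentage points higher from compound 2 to compound 3 (within the scatter) changed nothing beyond the scatter, a further lengthening is expected to behave alike, so the step of a number 1.8 percentage points higher from compound 3 to compound 4 (within the scatter) is expected to stay within the scatter. Compound 4 is therefore estimated at 90%, with a range from 80% to 98%.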

Compound 4, a percentage reported as activity, at one concentration (the size of the read-out at that concentration, not a potency): 97.2%
For compound 4 the middle estimate is 7.2 percentage points below the measured one; low and high end bracket the measured number.
By their numbers in this assay, from the lowest: compound 1; then compounds 2, 3 and 4 (each within the scatter of the next, the first and the last beyond it).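

In this assay, heptyl in place of hydrogen on a saturated chain carbon, ten or more bonds along the chain from an oxygen next to a carbonyl group, gives a number 9 percentage points higher from compound 3 to compound 4 (within the scatter), so even this large addition to an already long chain leaves the reading inside the usual scatter. Among neighbours in this series, the only step beyond the scatter remains a number 16 percentage points higher from compound 1 to compound 2 (beyond the scatter), while compound 4 adds a second step within it, after a number 2.2 percentage points higher from compound 2 to compound 3 (within the scatter), so the reading responds to lengthening only at the short end of the series. Nothing available here explains this behaviour.

As far as these compounds go, these compounds carry only saturated chains, so how a carboxylic acid or an amine in place of this chain would read stays open. Whether a still longer chain would also stay within the scatter of compound 4 is open too.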